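Swapping the chain on the triazole nitrogen for a ring

The source may report more compounds than this note shows. Statements on the series, on what has been measured and on what is new or still open speak of the compounds shown alone.

Measured compounds in a functional assay on HT-29 cells (Homo sapiens) for inhibition, read by luminescence and CellTiter-Glo, with a stated time of 24 h; on this read-out higher numbers stand for an effect only at larger amounts of compound and lower numbers for an effect already at smaller amounts:
Compound 1, `CC(C)Cn1nc(C(=O)N[C@H]2COc3ccccc3N(C)C2=S)nc1Cc1ccccc1`, gives 1230 nM.
Compound 2, `CN1C(=S)[C@@H](NC(=O)c2nc(Cc3ccccc3)n(CCC(F)(F)F)n2)COc2ccccc21`, gives 1550 nM.
Compound 3, `CN1C(=S)[C@@H](NC(=O)c2nc(Cc3ccccc3)n(CCCC#N)n2)COc2ccccc21`, gives 2400 nM.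

All three compounds share one core and differ only in the group on the aromatic nitrogen of the five-membered ring. Compound 3 carries the highest of the three numbers, yet it stands close to the others: a 2.0-fold higher number from compound 1 to compound 3 (0.29 log units; within the scatter) and a 1.5-fold higher number from compound 2 to compound 3 (0.19 log units; within the scatter), so none of the three numbers is separated from another by more than the scatter. Also a 1.3-fold higher number from compound 1 to compound 2 (0.10 log units; within the scatter).

Compound 4, `CN1C(=S)[C@@H](NC(=O)c2nc(Cc3ccccc3)n(C3CCOCC3)n2)COc2ccccc21`, has not been measured. Its difference from compound 3 is oxan-4-yl in place of 3-cyanopropyl on an aromatic nitrogen.

All three measured steps bear on this change, as each of them also swaps the group on that same aromatic nitrogen, and each stayed within the scatter. Within the data shown here, the group entering here is a ring rather than a chain, which none of the measured compounds has, so the comparison is looser. Still, the steps seen give no ground for a large movement in this assay in either direction. The expected result for compound 4 is therefore a 1.2-fold lower number from compound 3 to compound 4 (0.08 log units; within the scatter), that is, no step beyond the scatter.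

The estimate for compound 4 is 2000 nM, expected to fall between 700 nM and 6000 nM.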

Compound 4, half-maximal effective concentration: 2260 nM
The estimate for compound 4 lay 1.1-fold (0.05 log units) below the measured number, within the range that was stated.
By their numbers in this assay, from the lowest: compounds 1, 2, 4 and 3 (each within the scatter of the next).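

Among these compounds, compound 4 is the only compound here with a ring on this aromatic nitrogen, the six-membered non-aromatic oxan-4-yl, while the others all carry open chains. In this assay, replacing each chain with this ring stays within the scatter, whichever chain leaves: the steps read (a 1.1-fold lower number from compound 3 to compound 4 (0.03 log units; within the scatter)), (a 1.5-fold higher number from compound 2 to compound 4 (0.16 log units; within the scatter)) and (a 1.8-fold higher number from compound 1 to compound 4 (0.26 log units; within the scatter)). So the earlier finding for three open chains now extends to one ring at this position, and the four compounds cannot be separated by their numbers, although nothing measured here accounts for how little the numbers differ.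

The compounds shown leave open whether a chain ending in an amine or a carboxylic acid on this nitrogen would also stay within the scatter. They also leave open what a single methyl, or a cyclohexyl ring with no oxygen in it, would do at the same place.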